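Series notes: compound 1 to compound 3

The source may hold more compounds than are shown below. What is called first, only, known or untested is meant among the compounds shown, and "the series" means these compounds.

Measured compounds:
compound 1 `COc1ccc(-c2cnc3nc(N)nc(N4CCN(Cc5ccccc5F)CC4)c3n2)cc1OC` — 700 nM
compound 2 `CCOc1ccc(-c2cnc3nc(N)nc(OC(C)C)c3n2)cc1` — 10000 nM

In a functional assay on cells (T-cell, Homo sapiens) for inhibition (a higher number here means a weaker inhibitor, a lower number a stronger inhibitor), compound 1 gives 700 nM, the lowest of the two numbers at hand. Its nearest neighbour is compound 2, which in this assay gives 10000 nM; the gap between the two is beyond the scatter. Compound 2 differs from compound 1 in more than one place, so the two values only show that compound 1 is the stronger inhibitor of the pair and give no guide to any single change.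

Compound 3 `COc1ccc(-c2cnc3nc(N)nc(N4CCN(C(=O)COc5ccc(Cl)cc5)CC4)c3n2)cc1OC` is not yet measured. Relative to compound 1 the change is ((4-chlorophenoxy)methyl)carbonyl in place of 2-fluorobenzyl on an amine nitrogen in a ring. Going by the values given here, no pair of measured compounds isolates this change, so no measured step is available to anchor the expectation. The group that leaves and the group that enters both carry one six-membered aromatic ring of carbon only; what changes is the link to the ring nitrogen and the two hydrogen-bond acceptors that enter. The expected step from compound 1 to compound 3 is a 1.6-fold higher number from compound 1 to compound 3 (0.20 log units; within the scatter), a slight weakening that may well fall within the scatter. Compound 3 is expected to give 1100 nM in this assay, within the range 300 nM to 4000 nM.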

Compound 3, half-maximal inhibitory concentration: 0.5 nM
Compound 3: middle estimate off by 2200-fold (3.34 log units), on the high side, and the stated range ends above it.
By their numbers in this assay, from the lowest: compound 3; then compound 1; then compound 2.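

In this assay the swap of 2-fluorobenzyl for ((4-chlorophenoxy)methyl)carbonyl on the amine nitrogen in the ring gives a 1400-fold lower number from compound 1 to compound 3 (3.15 log units; beyond the scatter) and shows that this position, on which the earlier pair of compounds gave no single-change reading, has a very large effect on the value. Both groups carry one six-membered aromatic ring of carbon only, so such a ring on this nitrogen does not by itself set the value; the step goes with the new link to that ring, the hydrogen-bond acceptors that enter and the chlorine, taken together as one change. No measurement at hand accounts for the size of this step.

The compounds shown do not separate the carbonyl, the ether oxygen and the chlorine, and a 4-chlorobenzyl group or an unsubstituted phenoxyacetyl group on the same nitrogen would begin to divide the step among them. Also open, on these data alone, is whether ((4-chlorophenoxy)methyl)carbonyl gives a step of this size when the ethoxyphenyl group of compound 2 stands in place of the aryl group of compound 1.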